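The source may hold more compounds than are shown below. What is called first, only, known or untested is meant among the compounds shown, and "the series" means these compounds.

Measured so far in a physicochemical assay for solubility, using the shake flask method, in simulated intestinal fluid, measured as kinetic solubility, with a stated time of 2 h, at 25 degrees C, at pH 6.5; a higher number here means a more soluble compound, a lower number a less soluble compound:
Compound 1 `Cc1noc(-c2nc(C)c3c(c2N)C(=O)N(Cc2ccc(F)cc2)C3=O)n1`: < 5000 nM, a limit and not a number.
Compound 2 `Cc1noc(-c2nc(C)c3c(c2N)C(=O)N(CC2CCOCC2)C3=O)n1`: 5700 nM.

Among the measured compounds shown here, compound 2 carries the only actual number here, 5700 nM. Compound 3 `Cc1noc(-c2nc(C)c3c(c2N)C(=O)N(Cc2ccc(C(F)(F)F)cc2)C3=O)n1` is now to be measured, and it differs from compound 2 by 4-(trifluoromethyl)phenyl in place of oxan-4-yl on a saturated chain carbon bound to an amide-type nitrogen in a ring. For the measured compounds named here, one measured step bears on this change. It made the opposite kind of exchange at the same place, oxan-4-yl in place of 4-fluorophenyl, and gave an at least 1.1-fold higher number from compound 1 to compound 2 (0.05 log units; that floor lies within the scatter). From the compounds shown here alone, that step sets only a floor, so its true size remains unknown. With an aromatic group returning, a modest move to a lower number is expected, though it may not clear the scatter. The expected step is a 1.9-fold lower number from compound 2 to compound 3 (0.28 log units; within the scatter). Compound 3 may also be reported only as a limit. For compound 3 the estimate is 3000 nM, with an expected range from 900 nM to 6500 nM.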

Compound 3, solubility: < 5000 nM
Compound 3: only a limit was reported (the forecaster's own chance of this, stated with the estimate: 75%); the middle value is on the limit's open side.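

In this assay, compound 3 is reported only as a limit, < 5000 nM, and not as a number. From the compounds shown here alone, putting 4-(trifluoromethyl)phenyl in place of oxan-4-yl gives an at least 1.1-fold lower number from compound 2 to compound 3 (0.05 log units; that floor lies within the scatter), so the size of this exchange stays unknown in this direction, as it did in the reverse one. What is new is that a second aromatic group on this saturated chain carbon gives a limit rather than a number, so 4-fluorophenyl and 4-(trifluoromethyl)phenyl both end at the same reported limit, while only oxan-4-yl gives a number: the limit of < 5000 nM in this assay, at which 2 of the 3 values shown sit.

The step with trifluoromethyl in place of fluoro cannot be read, so these two aromatic groups stay unranked. Also open, going by these compounds, is whether an amine or a carboxylic acid on the same chain carbon would give a number or a limit.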